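The source may hold more compounds than are shown below. What is called first, only, known or untested is meant among the compounds shown, and "the series" means these compounds.

For the measured compounds named here, compound 3 `CC1CCN(c2c(S(=O)(=O)c3cccc(C#N)c3)cnc3ccc(Cl)cc23)CC1` sits second highest of the three numbers measured so far: in an assay on isolated protein for displacement of a labelled ligand from metabotropic glutamate receptor 5 (Homo sapiens), with a stated time of 60 min, tested at 1 uM (on this read-out lower numbers stand for less inhibition and higher numbers for more inhibition at the one concentration tested (going by the name of the read-out)), compound 3 gives 90%. Its nearest neighbour is compound 1 `Cc1ccc(S(=O)(=O)c2cnc3ccc(F)cc3c2N2CCC(C)CC2)cc1`, which in this assay gives 91%, a gap within the scatter; furthest away is compound 2 `CC1CCN(c2c(S(=O)(=O)c3ccccc3)cnc3ccc(F)cc23)CC1`, which gives 40%, a gap beyond the scatter. Going by the values given here, the only measured step with one change, a number 51 percentage points lower from compound 1 to compound 2 (beyond the scatter), concerns hydrogen in place of methyl on an aromatic carbon, a different kind of swap. Compound 4 `CC1CCN(c2c(S(=O)(=O)c3cccc(C#N)c3)cnc3ccc(F)cc23)CC1` differs from compound 3 by fluoro in place of chloro on an aromatic carbon. Among the compounds with values here, no measured step bears directly on a fluoro-for-chloro exchange, and compound 1 shows a fluoro compound can score high, so the step of a number 2 percentage points lower from compound 3 to compound 4 (within the scatter) is expected to stay within the scatter. Compound 4 is therefore estimated at 88%, between 74% and 98%.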

Compound 4, a percentage reported as inhibition, at one concentration (the size of the read-out at that concentration, not a potency): 93%
For compound 4 the middle estimate is 5 percentage points below the measured one; measured number inside the range.
By their numbers in this assay, from the lowest: compound 2; then compounds 3, 1 and 4 (each within the scatter of the next).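

Swapping chloro for fluoro on the aromatic carbon of the fused ring system leaves the read-out in this assay unchanged within the scatter, with a number 3 percentage points higher from compound 3 to compound 4 (within the scatter). With fluoro held in place, cyano on the aromatic ring attached to the sulfonyl sulfur matters greatly, giving a number 53 percentage points higher from compound 2 to compound 4 (beyond the scatter). 3-Cyanophenyl also serves as well as 4-methylphenyl, with a number 2 percentage points higher from compound 1 to compound 4 (within the scatter).

No supporting data are available to explain these results. On these data alone, it remains open whether bromo would match fluoro and chloro, or whether an amine could take the place of cyano.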